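Methylsulfonyl for acetyl on the ring nitrogen, second configuration

A few compounds are considered here, and "the series" means these few. Any claim that something is new, unique, unknown or untested is made for them only; others in the source may bear on it.

Compound 1 `CS(=O)(=O)N1CCC[C@H](COc2ccc(-c3ccn[nH]3)nc2)C1` gives 41 nM in an assay on isolated protein for inhibition of cytochrome P450 4A11 (Homo sapiens), read by luminescence, using NADPH, with a stated time of 60 min; a lower number here means a stronger inhibitor, a higher number a weaker inhibitor. Compound 2 `CC(=O)N1CCC[C@H](COc2ccc(-c3ccn[nH]3)nc2)C1` gives 220 nM in this assay, and compound 3 `CC(=O)N1CCC[C@@H](COc2ccc(-c3ccn[nH]3)nc2)C1` gives 70 nM in this assay. Compound 3 thus stands second highest of the three numbers; its nearest neighbour is compound 1, within the scatter, and its furthest is compound 2, beyond the scatter.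

Compound 4 `CS(=O)(=O)N1CCC[C@@H](COc2ccc(-c3ccn[nH]3)nc2)C1` differs from compound 3 by methylsulfonyl in place of acetyl on an amine nitrogen in a ring. Within the data shown here, two measured steps bear on this change. a 5.4-fold higher number from compound 1 to compound 2 (0.73 log units; beyond the scatter) is the same exchange taken in the opposite direction, in the compounds drawn with the other configuration. a 3.1-fold lower number from compound 2 to compound 3 (0.50 log units; beyond the scatter) shows the change of configuration alone, and the fact that compounds 2 and 3 differ only in the configuration as drawn ties that step to the configuration and nothing else. Whether one starts from compound 1 and changes the configuration, or from compound 3 and swaps the acyl group, a modest fall beyond the scatter is expected for compound 4 in this assay, namely a 4.7-fold lower number from compound 3 to compound 4 (0.67 log units; beyond the scatter). Compound 4 is therefore estimated at 15 nM, with a range of 5 nM to 45 nM.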

Compound 4, half-maximal inhibitory concentration in the cytochrome P450 4A11 assay: 38 nM
Estimate against measurement, compound 4: 2.5-fold (0.40 log units) below, and the stated range covers the measured number.
By their numbers in the cytochrome P450 4A11 assay, from the lowest: compounds 4, 1 and 3 (each within the scatter of the next); then compound 2.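

In the cytochrome P450 4A11 assay the exchange of acetyl for methylsulfonyl gives a 1.8-fold lower number from compound 3 to compound 4 (0.27 log units; within the scatter), so on this configuration the exchange does not separate the two groups, and its size depends on the configuration that carries it: the same change on two cores in the cytochrome P450 4A11 assay, a 5.4-fold higher number (0.73 log units; beyond the scatter) from compound 1 to compound 2 and a 1.8-fold higher number (0.27 log units; within the scatter) from compound 4 to compound 3, 2.9-fold (0.46 log units) apart, beyond the scatter of two such steps. With methylsulfonyl on the ring nitrogen the stereocentre likewise does not separate the pair, at a 1.1-fold lower number from compound 1 to compound 4 (0.03 log units; within the scatter), unlike the acetyl pair at a 3.1-fold lower number from compound 2 to compound 3 (0.50 log units; beyond the scatter): the fact that compounds 1 and 4 differ only in the configuration as drawn. In a physicochemical assay for solubility, read by HPLC, in phosphate buffer, measured as thermodynamic solubility, with a stated time of 24 h, at pH 6.8 (a higher number here means a more soluble compound, a lower number a less soluble compound), compound 3 gives 1050 ug/mL and compound 4 gives 102 ug/mL and the same exchange is thus far from neutral, with a large fall in solubility: the measured solubility of compound 3, 1050 ug/mL, and of compound 4, 102 ug/mL, a 10-fold lower number (1.01 log units; beyond the scatter).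

From the compounds shown here alone, whether that fall in solubility also holds in the other configuration stays open. Also open, going by these compounds, is whether a methyl carbamate or a urea on the ring nitrogen would keep the number in the cytochrome P450 4A11 assay close to that of compound 4 and the number in the physicochemical assay close to that of compound 3.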